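A few compounds are considered here, and "the series" means these few. Any claim that something is new, unique, unknown or untested is made for them only; others in the source may bear on it.

Measured so far:
- compound 1 `O=C(C[C@H](CCN1CCCCC1)NC(=O)c1cc(-c2ccccn2)n(C2CCCC2)n1)NC1CCC1`: "nd" (no result reported)
- compound 2 `CCc1ccccc1-c1cc(C(=O)N[C@@H](CCN2CCCCC2)CC(=O)NC2CCC2)nn1C1CCCC1`: 76.5%
- compound 3 `O=C(C[C@H](CCN1CCCCC1)NC(=O)c1cc(-c2c(F)cc(F)cc2F)n(C2CCCC2)n1)NC1CCC1`: "nd" (no result reported)

Compound 1 was tested in an ADME assay on microsomes from liver (Rattus norvegicus, strain Sprague-Dawley) for metabolic stability, read by LC-MS, using NADPH, with a stated time of 30 min, tested at 1 uM (on this read-out lower numbers stand for a less stable compound and higher numbers for a more stable compound), but no number is reported for it; the same is true of compound 3. So compound 1 stands nowhere on the scale of this read-out: the only compound with a number is compound 2, which in this assay gives 76.5%, a high value that marks a rather stable compound.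

The step to compound 4 `O=C(C[C@H](CCN1CCCCC1)NC(=O)c1cc(-c2ccccc2C2CC2)n(C2CCCC2)n1)NC1CCC1` changes one group on the shared core: 2-cyclopropylphenyl in place of pyridin-2-yl on an aromatic carbon. Going by the values given here, no measured pair shows this exact change, so its size and direction are unknown. Compound 2 carries a 2-ethylphenyl group in the same place and is stable; compound 4 carries a 2-cyclopropylphenyl group, which resembles that of compound 2 more than the pyridin-2-yl group of compound 1. On that single point of comparison, compound 4 is expected to stay at a level similar to that of compound 2 in this assay, about 70%, with a range of 45% to 90%.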

Compound 4, percent of the compound remaining: 70.1%
Compound 4: the middle estimate sits 0.1 percentage points below what was measured; the range from low to high includes it.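

In this assay, replacing ethyl with cyclopropyl on an aromatic carbon gives a number 6.4 percentage points lower from compound 2 to compound 4 (within the scatter). Going by these compounds alone, this is the first pair of measured compounds that differ in one place, and it shows that the two small carbon groups cannot be told apart on this read-out: the ring closure of cyclopropyl brings no change that exceeds the scatter. No supporting information bears on why the two compounds behave alike.

Compound 1 and compound 3 have no number, so the swap from pyridin-2-yl to 2-cyclopropylphenyl cannot be read, and the pair shows nothing about rings that carry nitrogen or fluorine at this place. Going by these compounds, it also remains open whether the stability would hold if an amine, a carboxylic acid or a longer carbon chain stood in place of the cyclopropyl group.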